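A Propyl to 4-Methylphenyl Step Weighed for Solubility

This account rests on a few compounds, and the source may have more. Where it says the series, first, only, none or still open, it means among the compounds named here.

Compound 3 `CCCC(=O)N1CCN(c2nc(=O)c3cc(C(F)(F)F)cc([N+](=O)[O-])c3s2)CC1` gives 2.46 ug/mL in a physicochemical assay for solubility, read by HPLC (on this read-out lower numbers stand for lower solubility and higher numbers for higher solubility), the lowest of the three numbers; compound 1 `CCC(=O)N1CCN(c2nc(=O)c3cc(C(F)(F)F)cc([N+](=O)[O-])c3s2)CC1` gives 3.29 ug/mL, and compound 2 `O=C(C1CC1)N1CCN(c2nc(=O)c3cc(C(F)(F)F)cc([N+](=O)[O-])c3s2)CC1` gives 52.9 ug/mL. The step of a 1.3-fold lower number from compound 1 to compound 3 (0.13 log units; within the scatter) lies within the scatter, whereas a 22-fold lower number from compound 2 to compound 3 (1.33 log units; beyond the scatter) is large. Compound 4 `Cc1ccc(C(=O)N2CCN(c3nc(=O)c4cc(C(F)(F)F)cc([N+](=O)[O-])c4s3)CC2)cc1` differs from compound 3 by 4-methylphenyl in place of propyl on a carbonyl carbon. For the measured compounds named here, no measured step places an aromatic ring on the carbonyl carbon, so the measured steps bear only loosely on it; they show that this carbonyl position can move solubility a great deal, as in a 16-fold higher number from compound 1 to compound 2 (1.21 log units; beyond the scatter), or hardly at all. Compound 4 is expected to give 1.5 ug/mL, with a range of 0.3 ug/mL to 10 ug/mL. The expected step of a 1.6-fold lower number from compound 3 to compound 4 (0.21 log units; within the scatter) is estimated to stay within the scatter.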

Compound 4, solubility: 6.7 ug/mL
The estimate for compound 4 lay 4.5-fold (0.65 log units) below the measured number; measured number inside the range.
By their numbers in this assay, from the lowest: compounds 3 and 1 (each within the scatter of the next); then compound 4; then compound 2.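

With 4-methylphenyl on the carbonyl carbon, the number in this assay stands above those of both open chains, with a 2.7-fold higher number from compound 3 to compound 4 (0.44 log units; beyond the scatter) and a 2.0-fold higher number from compound 1 to compound 4 (0.31 log units; beyond the scatter). It stays under the number for cyclopropyl, with a 7.9-fold lower number from compound 2 to compound 4 (0.90 log units; beyond the scatter), so an aromatic ring at this position falls between the open chains and cyclopropyl. Nothing measured here accounts for this order.

The compounds shown leave open where an unsubstituted phenyl ring, a pyridine ring or a chain ending in an amine would fall on this carbonyl carbon. They also leave open what part the methyl on the ring plays.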